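Swapping a fluoro for a methoxy on a shared core

A few compounds are considered here, and "the series" means these few. Any claim that something is new, unique, unknown or untested is made for them only; others in the source may bear on it.

Compound 1 `Nc1cc(N)c2nc(-c3ccccc3)c(Sc3ccc(F)cc3)nc2c1` and compound 2 `CCOC(=O)[C@H](CCC(=O)O)NC(=O)c1ccc(Oc2nc3cc(N)cc(N)c3nc2-c2ccccc2)cc1` share the same core and were both tested in a functional assay on SF-539 cells (Homo sapiens) for inhibition, read by sulforhodamine B assay, with a stated time of 48 h; on this read-out lower numbers stand for stronger inhibition of growth and higher numbers for weaker inhibition of growth. In this assay compound 1 gives 21400 nM, the lowest of the two numbers shown, while compound 2 gives 33900 nM; the two values lie within the scatter of each other, so no order between them can be read. Among the measured compounds shown here, no step between measured compounds is available to guide what a single change on this core does. Compound 3 `COc1ccc(Sc2nc3cc(N)cc(N)c3nc2-c2ccccc2)cc1` has not yet been measured. It differs from compound 1 in one place methoxy in place of fluoro on an aromatic carbon: the group leaving and the group entering sit on an aromatic carbon of a six-membered aromatic ring of carbon only, para to a large group. With nothing to show that this exchange matters, the step from compound 1 to compound 3 is expected to be small, a 1.2-fold higher number from compound 1 to compound 3 (0.07 log units; within the scatter), not beyond the scatter in either direction. Compound 3 is therefore estimated to give 25000 nM, within a range from 8000 nM to 70000 nM.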

Compound 3, concentration for 50% growth inhibition: 10000 nM
Beside the measured number, compound 3's estimate is 2.5-fold (0.40 log units) above it; low and high end bracket the measured number.
By their numbers in this assay, from the lowest: compound 3; then compounds 1 and 2 (each within the scatter of the next).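

In this assay, putting methoxy in place of fluoro on an aromatic carbon, para to a large group, gives a 2.1-fold lower number from compound 1 to compound 3 (0.33 log units; beyond the scatter). Among the compounds shown here, this is the first single-change step available on the shared core, and it shows that the group at this position can shift growth inhibition: the step is modest, but it lies beyond the usual scatter. Nothing measured here accounts for the size or direction of this step.

On these data alone, whether an amine, a carboxylic acid or a longer chain such as ethoxy on that same carbon would push the number further down or back up remains open. A single pair also cannot separate the effect of gaining methoxy from that of losing fluoro, a question that a plain hydrogen on that carbon could help to settle.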